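The source may hold more compounds than are shown below. What is called first, only, known or untested is meant among the compounds shown, and "the series" means these compounds.

Measured compounds in an in vitro assay on Sf9 cells for binding affinity to P2Y purinoceptor 1 (Homo sapiens); a lower number here means a stronger inhibitor, a higher number a weaker inhibitor:
compound 1, `CNc1nc(Cl)nc2c1ncn2[C@H]1C[C@H](OP(=O)(O)O)[C@]2(COP(=O)(O)O)C[C@H]12`, 2.5 nM
compound 2, `CNc1ncnc2c1ncn2[C@H]1C[C@H](OP(=O)(O)O)[C@]2(COP(=O)(O)O)C[C@H]12`, 17.6 nM
compound 3, `CNc1nc(C)nc2c1ncn2[C@H]1C[C@H](OP(=O)(O)O)[C@]2(COP(=O)(O)O)C[C@H]12`, 3.6 nM

The three share one core and differ only in the group on one aromatic carbon. Compound 3, with a methyl there, stands second highest of the three numbers in this assay. Its nearest neighbour is compound 1, where a 1.4-fold higher number from compound 1 to compound 3 (0.16 log units; within the scatter), a gap within the scatter. Its furthest is compound 2, where a 4.9-fold lower number from compound 2 to compound 3 (0.69 log units; beyond the scatter), a gap beyond the scatter. The remaining pair shows a 7.0-fold higher number from compound 1 to compound 2 (0.85 log units; beyond the scatter).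

Compound 4, `CCCCCCc1nc(NC)c2ncn([C@H]3C[C@H](OP(=O)(O)O)[C@]4(COP(=O)(O)O)C[C@H]34)c2n1`, has not yet been measured. It differs from compound 3 by pentyl in place of hydrogen on a saturated chain carbon bound to an aromatic carbon. The measured steps all concern that same aromatic carbon: replacing hydrogen by methyl or chloro gives a modest fall in the number, while methyl and chloro sit within the scatter of each other. None of them tells what a longer chain does; the change from methyl to hexyl goes well beyond anything measured.

Compound 4 is therefore expected to stay near compound 3, with an estimate of 5 nM (range 1.5 nM to 20 nM). The expected step is a 1.4-fold higher number from compound 3 to compound 4 (0.14 log units; within the scatter), which is not beyond the scatter.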

Compound 4, inhibition constant: 80 nM
Estimate against measurement, compound 4: 16-fold (1.20 log units) below; the measured number lies above the stated range.
By their numbers in this assay, from the lowest: compounds 1 and 3 (each within the scatter of the next); then compound 2; then compound 4.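

In this assay, extending the methyl of compound 3 to the hexyl of compound 4 gives a 22-fold higher number from compound 3 to compound 4 (1.35 log units; beyond the scatter) and so reverses the direction seen so far at this aromatic carbon, where methyl and chloro had both given a lower number than hydrogen. The hexyl chain also ends up worse than having no substituent at all, with a 4.5-fold higher number from compound 2 to compound 4 (0.66 log units; beyond the scatter) and a still wider gap to the chloro compound, shown by a 32-fold higher number from compound 1 to compound 4 (1.51 log units; beyond the scatter); a group at this carbon can therefore raise the number as well as lower it, and the size of the group's effect is not limited to the modest steps seen among the first three compounds. Nothing available accounts for this reversal.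

The compounds shown jump from methyl straight to hexyl, so they leave open where ethyl, propyl or butyl would fall and whether the number climbs steadily with length or turns upward at one particular chain length. They also leave open whether a longer chain would raise the number further, and whether a hexyl chain ending in an amine or a carboxylic acid would behave like the plain hexyl chain.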